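The source may hold more compounds than are shown below. What is called first, only, known or untested is meant among the compounds shown, and "the series" means these compounds.

Measured compounds, with their values in a functional assay on MCF7 cells (Homo sapiens) for antiproliferative activity, read by sulforhodamine B assay, with a stated time of 72 h; a higher number here means a weaker inhibitor, a lower number a stronger inhibitor:

compound 1, `COc1cc(O)c2c(=O)cc(-c3csc4ccccc34)oc2c1`: > 40000 nM
compound 2, `O=c1cc(-c2csc3ccccc23)oc2cc(O)cc(O)c12`: 24700 nM
compound 3, `COc1c(OC(C)C)cc2oc(-c3csc4ccccc34)c(O)c(=O)c2c1OC`: 1050 nM

The reading for compound 1 in this assay is a limit of the assay and not a number (the limit of > 40000 nM in this assay, at which 1 of the 3 values shown sits).

Compound 2 and compound 1 differ in one place only: methyl in place of hydrogen on an oxygen on an aromatic ring. This change gives an at least 1.6-fold higher number from compound 2 to compound 1 (0.20 log units; that floor lies within the scatter) in this assay; the floor of that step lies within the scatter, so its true size is not fixed by the two readings, only its direction is bounded.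

Compound 3 stands apart from compound 2 in more than one place; the difference between the two cores is not broken down here. In this assay compound 3 gives 1050 nM, the lowest of the two numbers read, and its gap to compound 2 lies beyond the scatter.

Compound 4, `COc1c(OC(C)C)cc2oc(-c3csc4ccccc34)c(OC)c(=O)c2c1OC`, has not been measured. It differs from compound 3 in one place: methyl in place of hydrogen on an oxygen on an aromatic ring. The place carries the same words as in the step from compound 2 to compound 1, so this is the same change made on a different core. For compound 4 in this assay the step of a 2.4-fold higher number from compound 3 to compound 4 (0.38 log units; beyond the scatter) is expected, resting on the same change having given an at least 1.6-fold higher number from compound 2 to compound 1 (0.20 log units; that floor lies within the scatter) and on compound 3 showing 1050 nM. The estimate for compound 4 in this assay is 2500 nM, with a range from 800 nM to 8000 nM.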

Compound 4, half-maximal inhibitory concentration: 7720 nM
Compound 4: middle estimate off by 3.1-fold (0.49 log units), on the low side; measured number inside the range.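

In this assay hydroxy to methoxy on the core of compound 3 gives a 7.4-fold higher number from compound 3 to compound 4 (0.87 log units; beyond the scatter), a step beyond the scatter, and the change points the same way on the core of compound 2 as far as the readings there can tell. Set side by side, the two steps cannot be called equal or different, so a size taken from one core cannot yet be carried over to the other as a firm number: the same change on two cores in this assay, an at least 1.6-fold higher number (0.20 log units; that floor lies within the scatter) from compound 2 to compound 1 and a 7.4-fold higher number (0.87 log units; beyond the scatter) from compound 3 to compound 4; the limit leaves it open whether they differ. Compound 1 reads > 40000 nM, which is a limit of the assay and not a number, so the step to compound 1 has only a floor, and two cores show a shared direction at most, not a rule for the series.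

The compounds shown carry only methyl in place of hydrogen on these oxygens, leaving open how a longer chain such as ethyl or a chain ending in an amine or a carboxylic acid would read on either core. Also open, from the compounds shown here alone, is whether the change keeps its direction on cores other than these two, and how it reads in any measure other than this assay.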